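This account rests on a few compounds, and the source may have more. Where it says the series, first, only, none or still open, it means among the compounds named here.

Measured so far:
compound 1 `c1ccc(CCCCNC2CCc3ccsc3CC2)cc1` — 62 nM
compound 2 `CCN(CCCCc1ccccc1)C1CCc2ccsc2CC1` — 12 nM

In an assay on membranes from brain for displacement of a labelled ligand from Sigma non-opioid intracellular receptor 1 (Cavia porcellus), read by scintillation counting, with a stated time of 120 min (a higher number here means a weaker inhibitor, a lower number a stronger inhibitor), compound 1 gives 62 nM, the highest of the two numbers; its nearest neighbour is compound 2 at 12 nM, giving a 5.2-fold lower number from compound 1 to compound 2 (0.71 log units; beyond the scatter) for ethyl in place of hydrogen on the amine nitrogen. Compound 3 `Brc1cc2c(s1)CCC(NCCCCc1ccccc1)CC2` differs from compound 1 by bromo in place of hydrogen on an aromatic carbon next to the ring sulfur. Going by the values given here, no measured step touches this aromatic ring, so the one step known gives no guide here. Compound 3 is therefore expected to show no change beyond the scatter, a 1.2-fold lower number from compound 1 to compound 3 (0.09 log units; within the scatter). The estimate for compound 3 is 50 nM, between 15 nM and 200 nM.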

Compound 3, inhibition constant: 14 nM
For compound 3 the middle estimate is 3.6-fold (0.55 log units) above the measured one; measured number outside the range, below it.
By their numbers in this assay, from the lowest: compounds 2 and 3 (each within the scatter of the next); then compound 1.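

In this assay, going by these compounds alone, bromo on an aromatic carbon next to the ring sulfur gives a 4.4-fold lower number from compound 1 to compound 3 (0.65 log units; beyond the scatter), the first measured step at this ring. This position therefore accepts a single heavy atom in place of hydrogen, and the read-out responds to the change beyond the scatter. No measurement available here explains the step.

As far as these compounds go, it remains open whether chloro or methyl on the same carbon would give a step of similar size. From the compounds shown here alone, it is also open whether bromo at this position and ethyl on the amine nitrogen would combine in one compound.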